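Aryl ether variation in a shared acid series

The source may report more compounds than this note shows. Statements on the series, on what has been measured and on what is new or still open speak of the compounds shown alone.

Measured so far:
Compound 1: `O=C(O)c1cc(-c2ccc(OCc3ccccc3)cc2)n(-c2ccccc2)n1`; an assay for displacement of a labelled ligand from E3 ubiquitin-protein ligase Mdm2 (Homo sapiens), read by fluorescence polarization, with a stated time of 30 min; on this read-out lower numbers stand for stronger inhibition and higher numbers for weaker inhibition: 19800 nM
Compound 2: `CC(C)Oc1ccc(-c2cc(C(=O)O)nn2-c2ccc(Oc3ccccc3)cc2)cc1`; this assay: 712 nM
Compound 3: `CC(C)Oc1ccc(-c2cc(C(=O)O)nn2-c2ccc(C(C)C)cc2)cc1`; this assay: 2140 nM

Compound 3 holds the second highest number of the three: compound 2 sits below it, by the step of a 3.0-fold higher number from compound 2 to compound 3 (0.48 log units; beyond the scatter), while compound 1 is the furthest from it, compound 1 giving 19800 nM where compound 3 gives 2140 nM.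

Compound 4 is `CC(C)c1ccc(-n2nc(C(=O)O)cc2-c2ccc(OCc3ccccc3)cc2)cc1`. It differs from compound 3 in one place: benzyl in place of isopropyl on an oxygen on an aromatic ring. Going by the values given here, no measured step touches this oxygen. Among the compounds with values here, the single measured step, a 3.0-fold higher number from compound 2 to compound 3 (0.48 log units; beyond the scatter), concerns the ring on the nitrogen and says nothing about what happens at the ether. Compound 1 carries the same benzyloxy group but also a plain phenyl on the nitrogen, so its high number cannot be assigned to the ether alone; compound 2 carries isopropoxy with a different nitrogen substituent again.

Within the data shown here, with no step bearing on the change, the working expectation for compound 4 in this assay is no step beyond the scatter, with a wide range in either direction, which means an expected step of a 1.2-fold higher number from compound 3 to compound 4 (0.07 log units; within the scatter). Compound 4 is accordingly estimated at 2500 nM, with a range from 700 nM to 9000 nM.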

Compound 4, inhibition constant: 616 nM
Compound 4: the middle estimate sits 4.1-fold (0.61 log units) above what was measured; measured number below the stated range.
By their numbers in this assay, from the lowest: compounds 4 and 2 (each within the scatter of the next); then compound 3; then compound 1.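

In this assay, the ether oxygen now has a reading of its own: a 3.5-fold lower number from compound 3 to compound 4 (0.54 log units; beyond the scatter), with benzyloxy replacing isopropoxy while the rest of the structure stays fixed, so at this position the larger group with its extra aromatic ring gives the lower number. With benzyloxy held constant, the second step, a 32-fold lower number from compound 1 to compound 4 (1.51 log units; beyond the scatter), comes from isopropyl in place of hydrogen on an aromatic carbon of the ring on the nitrogen, which separates the high number of compound 1 from the ether and ties it to that hydrogen. Nothing measured here explains either step.

The compounds shown leave open whether the benzyloxy step carries over when phenoxy, as in compound 2, replaces isopropyl on the ring on the nitrogen, since the ether change is read in only one pair. They also leave open whether the aromatic ring of benzyloxy is needed, which an ether such as cyclohexylmethoxy or a longer chain such as butoxy could address.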